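Ring-closed replacement on the shared core: two parallel comparisons

The source may hold more compounds than are shown below. What is called first, only, known or untested is meant among the compounds shown, and "the series" means these compounds.

Compound 1 `CC(C)NC(=N)c1ccc2cc(-c3cccc(OCCCCCCOc4ccccc4)c3)oc2c1` and compound 3 `CC(C)NC(=N)c1ccc2cc(-c3ccc(OCCCCCOc4ccccc4)cc3)oc2c1` are built on closely related cores; the difference between the two cores is not broken down here. In an ADME assay on L6 cells (Rattus norvegicus) for cytotoxicity, read by resazurin assay, with a stated time of 70 h (a lower number here means a stronger inhibitor, a higher number a weaker inhibitor), compound 1 gives 10100 nM, and compound 3 gives 10700 nM; these two numbers lie within the usual scatter of each other, so no order between them is read. Compound 2 `c1ccc(OCCCCCCOc2cccc(-c3cc4ccc(C5=NCCN5)cc4o3)c2)cc1` arises from compound 1 by the change (a group of 5 heavy atoms (3 carbon, 2 nitrogen; one five-membered non-aromatic ring with 2 hetero atoms) in place of a group of 6 heavy atoms (4 carbon, 2 nitrogen; no ring), on an aromatic carbon). In this assay compound 2 gives 1800 nM. The measured outcome of that change is a 5.6-fold lower number from compound 1 to compound 2 (0.75 log units; beyond the scatter), the only measured example of it among these compounds. Compound 4 `c1ccc(OCCCCCOc2ccc(-c3cc4ccc(C5=NCCN5)cc4o3)cc2)cc1` stands to compound 3 as compound 2 stands to compound 1, the change being (a group of 5 heavy atoms (3 carbon, 2 nitrogen; one five-membered non-aromatic ring with 2 hetero atoms) in place of a group of 6 heavy atoms (4 carbon, 2 nitrogen; no ring), on an aromatic carbon), at the same position of the core. The expectation for compound 4 rests on compound 1 to compound 2 giving a 5.6-fold lower number from compound 1 to compound 2 (0.75 log units; beyond the scatter) and on compound 3 giving 10700 nM in this assay, close to compound 1. The expected step is a 5.6-fold lower number from compound 3 to compound 4 (0.75 log units; beyond the scatter), to be read beside the measured 5.6-fold lower number from compound 1 to compound 2 (0.75 log units; beyond the scatter). Compound 4 is estimated at 1900 nM in this assay, with a likely range from 800 nM to 4500 nM.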

Compound 4, half-maximal inhibitory concentration: 3200 nM
The estimate for compound 4 lay 1.7-fold (0.23 log units) below the measured number; measured number inside the range.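

Working notes on carrying the change across cores. In this assay, putting the five-membered non-aromatic ring with 2 hetero atoms in place of the open six-heavy-atom group on the core of compound 3 gives a 3.3-fold lower number from compound 3 to compound 4 (0.52 log units; beyond the scatter). Set beside the earlier step, the change carries over with no readable difference in size: the same change on two cores in this assay, a 5.6-fold lower number (0.75 log units; beyond the scatter) from compound 1 to compound 2 and a 3.3-fold lower number (0.52 log units; beyond the scatter) from compound 3 to compound 4, 1.7-fold (0.22 log units) apart, within the scatter of two such steps. This rests on two matched pairs, so it supports a lower number on these two closely related cores only; it does not show that the step would hold on any other core, and it gives no reason for the step.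

Still open, as far as these compounds go, is whether another group on that aromatic carbon, such as an unsubstituted amidine or a carboxylic acid, would follow the same course in this assay. Also open, from the compounds shown here alone, is whether the step would keep its size with a longer chain on either core.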